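The source may hold more compounds than are shown below. What is called first, only, known or untested is meant among the compounds shown, and "the series" means these compounds.

The study concerns a series of nucleoside analogues built on one shared core and tested in a functional assay on K562 cells (Homo sapiens), read by MTT assay, with a stated time of 72 h; a lower number here means a stronger inhibitor, a higher number a weaker inhibitor. Compound 2 `Nc1nc2c(c(-c3ccccc3)cn2[C@@H]2O[C@H](CO)[C@@H](O)[C@H]2O)c(=O)[nH]1` carries a phenyl group on that core; in this assay compound 2 gives > 20000 nM, which is a limit of the assay and not a number. Compound 1 `Nc1nc(N)c2c(-c3ccsc3)cn([C@@H]3O[C@H](CO)[C@@H](O)[C@H]3O)c2n1` is a close relative; in this assay compound 1 gives > 20000 nM, again a limit of the assay. Compound 3 `CNc1ncnc2c1c(-c1cccs1)cn2[C@@H]1O[C@H](CO)[C@@H](O)[C@H]1O` completes the measured set; in this assay compound 3 gives > 20000 nM, also a limit. For the measured compounds named here, compound 2 therefore stands nowhere apart from its neighbours: every value seen so far sits at the limit of > 20000 nM in this assay, at which 3 of the 3 values shown sit, and no step between two measured compounds exists from which the size of a change can be read.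

Compound 4 `Nc1nc2c(c(-c3cc4ccccc4o3)cn2[C@@H]2O[C@H](CO)[C@@H](O)[C@H]2O)c(=O)[nH]1` differs from compound 2 in a single place: 1-benzofuran-2-yl in place of phenyl on an aromatic carbon. Going by the values given here, because all three known values sit at the limit of > 20000 nM in this assay, at which 3 of the 3 values shown sit, there is no measured step to lean on, and the expected step from compound 2 to compound 4 is a step that the limit leaves unreadable from compound 2 to compound 4, which is to say none that could be told from the scatter. Compound 4 is accordingly estimated to give 25000 nM in this assay, with a range from 6000 nM to 100000 nM, and most likely only a limit once more.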

Compound 4, half-maximal inhibitory concentration: > 20000 nM
Compound 4 was reported as a limit; the forecaster's own chance of this, stated with the estimate: 80%; the middle value does not contradict the limit.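

Compound 2 and compound 4 are both reported only as limits of the assay, so the change from phenyl to 1-benzofuran-2-yl yields no readable step in this assay. The compounds shown leave open whether any change on the shared core alters the value, because every result stands at one limit: the limit of > 20000 nM in this assay, at which 4 of the 4 values shown sit.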